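A few compounds are considered here, and "the series" means these few. Any claim that something is new, unique, unknown or untested is made for them only; others in the source may bear on it.

Measured so far:
- Compound 1, `COc1ccc(-c2cc(/C=C/C(=O)c3cc(OC)c(OC)c(OC)c3)[nH]n2)cc1OC`: 11%
- Compound 2, `COc1ccc(C(=O)/C=C/c2cc(-c3cc(OC)c(OC)c(OC)c3)n[nH]2)cc1`: -33%
- Compound 3, `COc1ccc(C(=O)/C=C/c2cc(-c3cc(OC)c(OC)c(OC)c3)n[nH]2)cc1OC`: -82%

In a functional assay on MDA-MB-231 cells (Homo sapiens) for cytotoxicity, read by sulforhodamine B assay, with a stated time of 48 h, tested at 10 uM (a higher number here means a weaker effect of the compound at the concentration tested, a lower number a stronger effect), compound 3 gives the lowest of the three numbers, with -82%. Its nearest neighbour is compound 2 at -33%, and the furthest is compound 1 at 11%, both gaps lying beyond the usual scatter.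

Compound 4, `COc1cc(C(=O)/C=C/c2cc(-c3cc(OC)c(OC)c(OC)c3)n[nH]2)cc(OC)c1OC`, has not yet been measured. It differs from compound 3 by methoxy in place of hydrogen on an aromatic carbon. Within the data shown here, the one measured step that resembles this change is the step within the same ring that turned compound 2 into compound 3: a number 49 percentage points lower from compound 2 to compound 3 (beyond the scatter). That step was the same kind of change, a methoxy in place of hydrogen on an aromatic carbon, and it moved the number strongly downward.

On that single precedent, the number for compound 4 in this assay is expected to move further downward, though the room below compound 3 is limited, so the expected step is a number 8 percentage points lower from compound 3 to compound 4 (within the scatter). Compound 4 is therefore estimated at -90%, within a range from -100% to -65%.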

Compound 4, a percentage reported as activity, at one concentration (the size of the read-out at that concentration, not a potency): -53%
Compound 4: the middle estimate sits 37 percentage points below what was measured; the whole stated range lies below it.
By their numbers in this assay, from the lowest: compound 3; then compound 4; then compound 2; then compound 1.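

In this assay, methoxy in place of hydrogen does not always push the number down: at this place on the six-membered aromatic ring, ortho to a methoxy group, it gives a number 29 percentage points higher from compound 3 to compound 4 (beyond the scatter), the opposite direction from the earlier step on that ring, a number 49 percentage points lower from compound 2 to compound 3 (beyond the scatter). So on this ring, the outcome of the change depends on where the methoxy lands, and a further methoxy brings no further gain. Compound 4 can also be reached from the core of compound 1, giving a number 64 percentage points lower from compound 1 to compound 4 (beyond the scatter), so the change does lower the number on the other ring, and its size differs between the two cases that go downward: the same change on two cores in this assay, a number 49 percentage points lower (beyond the scatter) from compound 2 to compound 3 and a number 64 percentage points lower (beyond the scatter) from compound 1 to compound 4, 15 percentage points apart, beyond the scatter of two such steps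

On these data alone, it remains open whether the rise comes from methoxy itself or from any group at this place. A hydroxyl group or an amine there would help to separate the two.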